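Swapping an Ester for an Amide in Compound 3

This account rests on a few compounds, and the source may have more. Where it says the series, first, only, none or still open, it means among the compounds named here.

Of the compounds shown here, three from one series have been tested for how quickly liver preparations break them down. Compound 1 `CC(C)NC(=O)[C@H]1CC[C@@H](n2/c(=N/C(=O)c3ccc(F)c(F)c3)[nH]c3ccc(CN4CCC(C(C)(C)O)CC4)cc32)CC1` gives 19 mL.min-1.g-1 in an in vitro ADME assay on microsomes from liver (Rattus norvegicus) for metabolic stability (on this read-out lower numbers stand for slow clearance and higher numbers for fast clearance), and compound 2 `CC(C)NC(=O)[C@H]1CC[C@@H](n2/c(=N/C(=O)c3ccc(C#N)c(F)c3)[nH]c3ccc(CN4CCC(C(C)(C)O)CC4)cc32)CC1` gives 29 mL.min-1.g-1. The step of a 1.5-fold higher number from compound 1 to compound 2 (0.18 log units; within the scatter) shows that these two hardly differ. Compound 3 `CCOC(=O)[C@H]1CC[C@@H](n2/c(=N/C(=O)c3ccccc3)[nH]c3ccc(CN4CCCCC4)cc32)CC1` stands apart: in this assay compound 3 gives 706 mL.min-1.g-1, the highest of the three numbers and beyond the scatter from both others.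

Compound 4 `CCN(CC)C(=O)[C@H]1CC[C@@H](n2/c(=N/C(=O)c3ccccc3)[nH]c3ccc(CN4CCCCC4)cc32)CC1` is compound 3 with one change, (diethylamino in place of ethoxy on a carbonyl carbon). Among the measured compounds shown here, no measured step touches this change: the only step on hand, cyano in place of fluoro, sits on a different part of the molecule and was within the scatter, so it gives no guide. Compounds 1 and 2 carry a different group on that carbonyl carbon and differ elsewhere as well, so their low numbers cannot simply be read across. The expectation for compound 4 in this assay is therefore uncertain, and the estimated step of a 2.4-fold lower number from compound 3 to compound 4 (0.37 log units; beyond the scatter) is kept modest with a wide range. Compound 4 is expected to give 300 mL.min-1.g-1, between 80 mL.min-1.g-1 and 900 mL.min-1.g-1.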

Compound 4, intrinsic clearance in microsomes: 682 mL.min-1.g-1
Compound 4: middle estimate off by 2.3-fold (0.36 log units), on the low side; low and high end bracket the measured number.
By their numbers in this assay, from the lowest: compounds 1 and 2 (each within the scatter of the next); then compounds 4 and 3 (each within the scatter of the next).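

In this assay the swap of ethoxy for diethylamino on this carbonyl carbon gives a 1.0-fold lower number from compound 3 to compound 4 (0.02 log units; within the scatter) and so separates nothing. With the rest of the molecule held the same, ethoxycarbonyl and diethylcarbamoyl cannot be told apart on this read-out, and clearance is fast with either group, so the high number of compound 3 does not hang on the ethoxycarbonyl group alone. Nothing available explains why the two groups give such closely matched numbers.

The compounds shown leave open whether a different group on this carbonyl carbon, such as methylamino or the hydroxyl of a carboxylic acid, would give a different number. They also leave open how much of the wide gap to compounds 1 and 2 belongs to this position, as those compounds differ from compound 3 and compound 4 in more than one place.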